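A few compounds are considered here, and "the series" means these few. Any claim that something is new, unique, unknown or untested is made for them only; others in the source may bear on it.

Measured in a functional assay on T47D cells (Homo sapiens) for antiproliferative activity, read by MTT assay, with a stated time of 72 h; on this read-out lower numbers stand for stronger inhibition and higher numbers for weaker inhibition:
compound 1 `O=C(Nc1ccc(Cl)c(-c2nnc3c(Cl)cccn23)c1)c1ccc(C(F)(F)F)cc1Cl` gives > 100000 nM, which is a limit of the assay.
compound 2 `O=C(Nc1ccc(Cl)c(-c2nnc3c(Cl)cccn23)c1)c1ccc(Cl)cc1Cl` gives > 100000 nM, likewise a limit.

Compound 2 therefore sits at the limit of > 100000 nM in this assay, at which 2 of the 2 values shown sit, with no number of its own. The step that the two limits leave unreadable from compound 1 to compound 2 cannot be read, since both its ends are limits. Compound 3 `CS(=O)(=O)c1ccc(C(=O)Nc2ccc(Cl)c(-c3nnc4c(Cl)cccn34)c2)c(Cl)c1` differs from compound 2 by methylsulfonyl in place of chloro on an aromatic carbon. Among the compounds with values here, no measured step bears on this change, and the one step available gives no size. The expected step that the limit leaves unreadable from compound 2 to compound 3 is thus an estimate anchored only on the limit at which compound 2 stands. Compound 3 is expected in this assay at 150000 nM, within 30000 nM to 1000000 nM, most probably again reported as a limit.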

Compound 3, half-maximal inhibitory concentration: > 100000 nM
Compound 3 was reported as a limit; the forecaster's own chance of this, stated with the estimate: 75%; the middle value does not contradict the limit.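

No new step can be read among compound 1, compound 2 and compound 3, which all stand at one limit: the limit of > 100000 nM in this assay, at which 3 of the 3 values shown sit.

Left open is whether trifluoromethyl, chloro and methylsulfonyl differ at all in their effect on the inhibition read-out.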